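From compound 1 to compound 4: one added chloro

A few compounds are considered here, and "the series" means these few. Any claim that something is new, unique, unknown or untested is made for them only; others in the source may bear on it.

Values so far in an ADME assay on cells (Macrophage, Mus musculus) for cytotoxicity, read by resazurin assay, with a stated time of 3 days; a lower number here means a stronger inhibitor, a higher number a weaker inhibitor
compound 1 `O=C(Nc1cccc(C(F)(F)F)c1)c1cc(Cl)ccc1O` gives 5900 nM
compound 2 `O=C(O)c1cccc(NC(=O)c2cc(Cl)ccc2O)c1` gives > 60000 nM
compound 3 `CCOC(=O)c1cccc(NC(=O)c2cc(Cl)ccc2O)c1` gives 17000 nM

Compound 2 gives > 60000 nM, and this value is a limit of the assay.

Compound 1 holds the lowest number of the three, and its steps to both other compounds lie beyond the scatter. Compound 4 `O=C(Nc1cc(C(F)(F)F)ccc1Cl)c1cc(Cl)ccc1O` differs from compound 1 by chloro in place of hydrogen on an aromatic carbon, ortho to a large group and para to a trifluoromethyl group (chloro in place of hydrogen on an aromatic carbon).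

Going by the values given here, no measured step adds a chloro. The nearest steps replace the trifluoromethyl group instead: the change is an at least 10-fold higher number from compound 1 to compound 2 (1.00 log units; beyond the scatter) in one case and a 2.9-fold higher number from compound 1 to compound 3 (0.46 log units; beyond the scatter) in the other. The remaining step, an at least 3.5-fold lower number from compound 2 to compound 3 (0.54 log units; beyond the scatter) alters only the group that replaced it. Compound 4 keeps the trifluoromethyl group, and a step of those sizes is not expected.

The step expected is a 1.5-fold lower number from compound 1 to compound 4 (0.17 log units; within the scatter) and no change beyond the scatter is foreseen, with only a slight lean towards a lower number. The estimated value for compound 4 is 4000 nM within an expected range of 1500 nM to 11000 nM.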

Compound 4, half-maximal inhibitory concentration: 3500 nM
Estimate against measurement, compound 4: 1.1-fold (0.06 log units) above; low and high end bracket the measured number.
By their numbers in this assay, from the lowest: compounds 4 and 1 (each within the scatter of the next); then compound 3. At a limit, above all of these: compound 2.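

In this assay the entry of chloro in place of hydrogen on an aromatic carbon, ortho to a large group and para to a trifluoromethyl group, brings a 1.7-fold lower number from compound 1 to compound 4 (0.23 log units; within the scatter) and so shows that this position accepts a chloro without a change beyond the scatter. Going by these compounds alone, the earlier steps all replaced the trifluoromethyl group itself and each lay beyond the scatter, whereas this change leaves that group in place and acts elsewhere on its ring, so compound 4 is the first view of this position. Nothing given here bears on a reason for this step.

On these data alone, a single chloro says little about this position as a whole, and it remains open whether a larger or different group there, such as a methoxy group, an amine or a carboxylic acid, would also stay within the scatter of compound 1. As far as these compounds go, it is equally open whether the same chloro would give a step of this size with ethoxycarbonyl or carboxy in place of the trifluoromethyl group, as in compound 3 and compound 2.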